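A Methoxyphenyl Swap on a Weakly Active Triterpenoid Ester

The compounds below may be only part of what the source reports. "The series", "measured", "known", "first", "only" and "open" are said of these compounds alone.

Three esters built on one shared core have been tested in a functional assay on A549 cells (Homo sapiens) for antiproliferative activity, read by MTT assay, with a stated time of 48 h; on this read-out higher numbers stand for weaker inhibition and lower numbers for stronger inhibition. Compound 1 `C/C(=C\CC/C(C)=C/CC[C@@H]1[C@@]2(C)CCC(=O)C(C)(C)[C@H]2CC[C@@]1(C)O)CC/C=C(\C)C(=O)OCc1cn(-c2cccc(Cl)c2)nn1` gives 147000 nM in this assay. Compound 2 `C/C(=C\CC/C(C)=C/CC[C@@H]1[C@@]2(C)CCC(=O)C(C)(C)[C@H]2CC[C@@]1(C)O)CC/C=C(\C)C(=O)OCc1cn(-c2ccc(F)c(Cl)c2)nn1` reaches only the limit of the assay, > 150000 nM, so no number is known for it. Compound 3 `C/C(=C\CC/C(C)=C/CC[C@@H]1[C@@]2(C)CCC(=O)C(C)(C)[C@H]2CC[C@@]1(C)O)CC/C=C(\C)C(=O)OCc1cn(-c2ccc(C(C)(C)C)cc2)nn1` likewise returns the limit > 150000 nM, a boundary of the assay rather than a number. Compound 3 thus stands at the limit of > 150000 nM in this assay, at which 2 of the 3 values shown sit.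

Compound 4 `COc1ccccc1-n1cc(COC(=O)/C(C)=C/CC/C(C)=C/CC/C(C)=C/CC[C@@H]2[C@@]3(C)CCC(=O)C(C)(C)[C@H]3CC[C@@]2(C)O)nn1` differs from compound 3 in one place: 2-methoxyphenyl in place of 4-(tert-butyl)phenyl on an aromatic nitrogen. The measured steps that bear on this are earlier exchanges of the aryl group on the same nitrogen. The step of an at least 1.0-fold higher number from compound 1 to compound 3 (0.00 log units; that floor lies within the scatter) and the step that the two limits leave unreadable from compound 2 to compound 3 show that no aryl exchange among these three compounds has moved the read-out beyond the scatter. The same is expected here, so the expected step is a number no higher from compound 3 to compound 4 (the limit leaves the size open), with no direction beyond the scatter. Compound 4 is estimated at 150000 nM, within 70000 nM to 320000 nM, and it may again reach only the assay limit.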

Compound 4, half-maximal inhibitory concentration: > 150000 nM
Compound 4 ended at the assay's limit (the forecaster's own chance of this, stated with the estimate: 60%); the middle value lies on the limit itself.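

A 2-methoxyphenyl group, whose oxygen gives it one hydrogen-bond acceptor where 4-(tert-butyl)phenyl has none, now sits on this aromatic nitrogen, yet in this assay compound 4 gives only a limit of the assay and not a number, joining the others there: the limit of > 150000 nM in this assay, at which 3 of the 4 values shown sit. The swap also takes 10 heavy atoms away and puts 8 in their place, with no readable gain. Within the data shown here, the one readable step is an at least 1.0-fold higher number from compound 1 to compound 4 (0.00 log units; that floor lies within the scatter) and so shows nothing beyond the scatter, while the steps to compound 4 from compound 2 and from compound 3 cannot be read, with limits at both ends.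

From the compounds shown here alone, whether an amine or a carboxylic acid on the aryl ring, or a longer alkyl chain in its place, would give a true number remains open. So does the effect of any change to the ester link or the shared core.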